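This account rests on a few compounds, and the source may have more. Where it says the series, first, only, none or still open, it means among the compounds named here.

Compound 1 `CCC1(Cc2ccccc2)OS(=O)(=O)C=C1OCc1ccc([N+](=O)[O-])cc1` has been run in an ADME assay on HEL cells (Homo sapiens) for cytotoxicity, with a stated time of 3 days; on this read-out higher numbers stand for lower toxicity in this test and lower numbers for higher toxicity in this test. For compound 1 the result is only a limit of the test, < 200000 nM, not an exact number (the limit of < 200000 nM in this assay, at which 1 of the 2 values shown sits). A second member of the same series, compound 2 `CC(C)CC1(Cc2ccccc2)OS(=O)(=O)C=C1OCc1ccccc1`, was also tested; in this assay compound 2 gives 102000 nM. Compound 3 `CCC1(Cc2ccccc2)OS(=O)(=O)C=C1OCc1cccc(Cl)c1` has not yet been measured. It differs from compound 1 in one place: 3-chlorophenyl in place of 4-nitrophenyl on a saturated chain carbon bound to an oxygen on an unsaturated carbon. Among the measured compounds shown here, no measured pair shows this kind of swap, so the step is expected to stay within the usual scatter a step that the limit leaves unreadable from compound 1 to compound 3. In this assay compound 3 is expected to give about 110000 nM, with a likely range from 40000 nM to 250000 nM.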

Compound 3, half-maximal cytotoxic concentration: 50000 nM
Estimate against measurement, compound 3: 2.2-fold (0.34 log units) above, within the range that was stated.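

No size can be given for the step from compound 1 to compound 3, because compound 1 has only a limit as its result: the limit of < 200000 nM in this assay, at which 1 of the 3 values shown sits. The compounds shown leave open whether 3-chlorophenyl in place of 4-nitrophenyl changes the result in this assay.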